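The source may report more compounds than this note shows. Statements on the series, on what has been measured and on what is new or still open speak of the compounds shown alone.

Measured compounds:
Compound 1, `CNC(=O)c1cc(Oc2ccc3nc(Nc4ccccc4Oc4ccccc4)ncc3c2)ccn1`: < 1 10^-6 cm/s
Compound 2, `CNC(=O)c1cc(Oc2ccc3nc(Nc4cccc(C(F)(F)F)c4)ncc3c2)ccn1`: < 1 10^-6 cm/s

In an ADME assay on Caco-2 cells (Homo sapiens) for permeability, in the apical to basolateral direction (a higher number here means that the compound crosses the layer faster, a lower number that the compound crosses the layer more slowly), compound 2 gives < 1 10^-6 cm/s, which is a limit of the assay and not a number. Compound 1 likewise gives only < 1 10^-6 cm/s in this assay, again a limit. Going by the values given here, both measured compounds therefore sit at the limit of < 1 10^-6 cm/s in this assay, at which 2 of the 2 values shown sit, and no step between measured compounds can be drawn, so where compound 2 stands relative to anything else is not known beyond this limit.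

Compound 3, `CNC(=O)c1cc(Oc2ccc3nc(Nc4ccc(OC)cc4)ncc3c2)ccn1`, differs from compound 2 in one place: 4-methoxyphenyl in place of 3-(trifluoromethyl)phenyl on a nitrogen on an aromatic ring. Among the compounds with values here, with no measured step to lean on, the step from compound 2 to compound 3 is expected to be small, an at least 1.5-fold higher number from compound 2 to compound 3 (0.17 log units; that floor lies within the scatter), with no direction that can be trusted beyond the scatter. For compound 3 in this assay the permeability is estimated at 1.5 10^-6 cm/s, within a range from 0.3 10^-6 cm/s to 6 10^-6 cm/s.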

Compound 3, apparent permeability: < 1 10^-6 cm/s
Compound 3: a limit, no number; the forecaster's own chance of this, stated with the estimate: 50%; middle value at least 1.5-fold (0.17 log units) from the limit.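

No step from compound 2 to compound 3 can be read in this assay, because both results are limits of the assay and not numbers: the limit of < 1 10^-6 cm/s in this assay, at which 3 of the 3 values shown sit.

As far as these compounds go, whether compound 2 and compound 3 differ at all beneath that shared limit remains open.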